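A few compounds are considered here, and "the series" means these few. Any claim that something is new, unique, unknown or untested is made for them only; others in the source may bear on it.

Measured compounds:
- compound 1, `C=CCCCn1c(Cc2cc(OC)c(OC)c(OC)c2)nc2c(N)nc(F)nc21`: 44700 nM in a functional assay on MCF7 cells (Homo sapiens) for antiproliferative activity; on this read-out lower numbers stand for stronger inhibition and higher numbers for weaker inhibition
- compound 2, `CC/C=C/Cn1c(Cc2cc(OC)c(OC)c(OC)c2)nc2c(N)ncnc21`: 46800 nM in this assay

Among the measured compounds shown here, only two compounds have been measured, and they have no single-point structural link between them, so no step can be drawn from one to the other. Compound 2 sits within the usual scatter of compound 1, so the two numbers cannot be told apart; both stand far up the scale, meaning weak inhibition of cell growth.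

Compound 3, `C#CCCCn1c(Cc2cc(OC)c(OC)c(OC)c2)nc2c(N)ncnc21`, has not yet been measured. It differs from compound 2 by but-3-yn-1-yl in place of but-1-en-1-yl on a saturated chain carbon bound to an aromatic nitrogen. The shared core and the trimethoxybenzyl arm stay as they are; only the small four-carbon chain changes its unsaturation.

For the measured compounds named here, with no measured step of this kind to lean on, the expectation is that the change from compound 2 to compound 3 brings no step beyond the scatter in this assay, estimated as a 1.0-fold lower number from compound 2 to compound 3 (0.02 log units; within the scatter). For compound 3 the estimated value is 45000 nM, with an expected range from 18000 nM to 110000 nM.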

Compound 3, half-maximal inhibitory concentration: 24000 nM
The estimate for compound 3 lay 1.9-fold (0.27 log units) above the measured number; the range from low to high includes it.
By their numbers in this assay, from the lowest: compounds 3, 1 and 2 (each within the scatter of the next).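

Among the compounds shown here, this is the first step that can be read at this position: with but-3-yn-1-yl in place of but-1-en-1-yl on a saturated chain carbon bound to an aromatic nitrogen, this assay shows a 2.0-fold lower number from compound 2 to compound 3 (0.29 log units; within the scatter) as the outcome. Replacing the double bond in this four-carbon chain with a triple bond therefore gives no difference that can be told apart from repeat-measurement scatter. Nothing available here explains this result.

The compounds shown leave open whether a fully saturated butyl chain, a longer chain or a chain ending in an amine would give a step beyond the scatter at this position. They also leave open whether the same swap would behave alike on the core of compound 1, which carries a fluorine.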